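This account rests on a few compounds, and the source may have more. Where it says the series, first, only, none or still open, it means among the compounds named here.

Three compounds have numbers in an ADME assay on HEK293 cells (Homo sapiens) for cytotoxicity, read by MTT assay, with a stated time of 48 h; on this read-out higher numbers stand for weaker inhibition and lower numbers for stronger inhibition:

Compound 1, `Cc1ccc(S(=O)(=O)/N=C(/CCNC2=CC(=O)c3ccccc3C2=O)Nc2ccc(F)cc2)cc1`: 55100 nM
Compound 2, `Cc1ccc(S(=O)(=O)/N=C(/CCNC2=CC(=O)c3ccccc3C2=O)Nc2cccc(C)c2)cc1`: 56200 nM
Compound 3, `COc1ccc(N/C(CCNC2=CC(=O)c3ccccc3C2=O)=N\S(=O)(=O)c2ccc(C)cc2)c(OC)c1`: 83000 nM

All three share one core and differ only in the group carried on an amine nitrogen. Compound 3 sits at the upper end of the three numbers, but the step of a 1.5-fold higher number from compound 2 to compound 3 (0.17 log units; within the scatter) and the step of a 1.5-fold higher number from compound 1 to compound 3 (0.18 log units; within the scatter) both lie within the scatter, so the three readings cannot be told apart. The step of a 1.0-fold higher number from compound 1 to compound 2 (0.01 log units; within the scatter) is likewise flat.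

Compound 4, `Cc1ccc(S(=O)(=O)/N=C(/CCNC2=CC(=O)c3ccccc3C2=O)NCc2ccccc2)cc1`, has not yet been measured. It differs from compound 3 in one place: benzyl in place of 2,4-dimethoxyphenyl on an amine nitrogen. Every measured step bears on this spot, since each swaps one group for another on the same amine nitrogen, and none of them moved the number beyond the scatter. Benzyl itself appears in no measured compound, so the data give no direct reading on it, but the three flat steps suggest that exchanging the group at this position leaves the cytotoxicity reading roughly unchanged. For compound 4 the expected step of a 1.3-fold lower number from compound 3 to compound 4 (0.11 log units; within the scatter) is therefore none beyond the scatter. Compound 4 is estimated at 65000 nM, with a range from 35000 nM to 120000 nM.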

Compound 4, half-maximal inhibitory concentration: 80200 nM
For compound 4 the middle estimate is 1.2-fold (0.09 log units) below the measured one, within the range that was stated.
By their numbers in this assay, from the lowest: compounds 1, 2, 4 and 3 (each within the scatter of the next).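

Benzyl is the first group in this set that reaches the amine nitrogen through a carbon, rather than placing an aromatic ring on it directly, and this difference leaves no mark on the reading in this assay (a 1.0-fold lower number from compound 3 to compound 4 (0.01 log units; within the scatter)). The same holds against the two other aromatic groups (a 1.4-fold higher number from compound 2 to compound 4 (0.15 log units; within the scatter)) and (a 1.5-fold higher number from compound 1 to compound 4 (0.16 log units; within the scatter)), so across these four compounds the position accepts both kinds of attachment without a step beyond the scatter. The exchange of 2,4-dimethoxyphenyl for benzyl also replaces 10 heavy atoms with 7 and drops the hydrogen-bond acceptors of the leaving group, yet nothing available here accounts for the flat readings.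

As far as these compounds go, all four groups still carry a six-membered aromatic ring of carbon only, so it remains open whether the readings stay this close with a plain alkyl chain, or with an amine or a carboxylic acid added to the group on this nitrogen. The compounds shown also leave open whether a change elsewhere on the shared core would move the number in this assay.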